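From 3-Bromophenyl to 2-Methoxyphenyl: Compound 2 to Compound 3

The source may report more compounds than this note shows. Statements on the series, on what has been measured and on what is new or still open speak of the compounds shown alone.

In a functional assay on MCF7 cells (Homo sapiens) for cytotoxicity, read by sulforhodamine B assay, with a stated time of 48 h (a lower number here means a stronger inhibitor, a higher number a weaker inhibitor), compound 1 (`COc1cccc(/C=C/C(=O)c2cccc(-c3cccc(F)c3)c2)c1OC`) gives 11700 nM and compound 2 (`O=C(/C=C/c1cccc(Br)c1)c1cccc(-c2cccc(F)c2)c1`) gives 12700 nM. These two numbers lie within the usual scatter of each other, so compound 2 stands level with compound 1. Among the compounds with values here, the two do not form a pair differing in a single place, so no measured step is available as a guide.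

Compound 3 (`COc1ccccc1/C=C/C(=O)c1cccc(-c2cccc(F)c2)c1`) carries 2-methoxyphenyl in place of 3-bromophenyl on a double-bonded chain carbon bound to a double-bonded chain carbon. The group at that place also differs in compound 1, which still gives 11700 nM, so no change beyond the scatter is expected in this assay. The estimated step of a 1.3-fold lower number from compound 2 to compound 3 (0.10 log units; within the scatter) therefore has no meaningful direction. The expected value for compound 3 is 10000 nM, within an estimated range of 4500 nM to 22000 nM.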

Compound 3, half-maximal inhibitory concentration: 18900 nM
The estimate for compound 3 lay 1.9-fold (0.28 log units) below the measured number; measured number inside the range.
By their numbers in this assay, from the lowest: compounds 1, 2 and 3 (each within the scatter of the next).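

In this assay, 2-methoxyphenyl in place of 3-bromophenyl gives a 1.5-fold higher number from compound 2 to compound 3 (0.17 log units; within the scatter), so this exchange at the position produces no readable difference, even though the bromine leaves and an oxygen enters. Hydrogen in place of methoxy on an aromatic carbon gives a 1.6-fold higher number from compound 1 to compound 3 (0.21 log units; within the scatter), so compound 1 and compound 3 also stand level, and this methoxy group makes no readable difference here. No measurement is available that could explain these results.

All three compounds carry only bromine or methoxy groups on this ring, so the results show how far the number can stay level only across that small set. On these data alone, whether an amine or a carboxylic acid on the ring would move the number beyond the scatter remains open.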